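Trifluoromethoxy in place of methyl on compound 2

This account rests on a few compounds, and the source may have more. Where it says the series, first, only, none or still open, it means among the compounds named here.

Compound 1 `COc1ccc(/C=C/C(=O)c2ccc(Nc3cc(C)nc4nc(SCc5nc6ccccc6[nH]5)nn34)cc2)cc1F` gives 140 nM in a functional assay on SW-620 cells (Homo sapiens) for cytotoxicity, read by MTT assay, with stated times of 4 h and 72 h, tested at 2 uM; a lower number here means a stronger inhibitor, a higher number a weaker inhibitor
Compound 2 `Cc1ccc(/C=C/C(=O)c2ccc(Nc3cc(C)nc4nc(SCc5nc6ccccc6[nH]5)nn34)cc2)cc1` gives 1520 nM in this assay

Compound 2 has the higher of the two numbers in this assay and is the weaker inhibitor. Compound 3 `Cc1cc(Nc2ccc(C(=O)/C=C/c3ccc(OC(F)(F)F)cc3)cc2)n2nc(SCc3nc4ccccc4[nH]3)nc2n1` has trifluoromethoxy in place of methyl on an aromatic carbon. Within the data shown here, one measured step bears on this ring, and it is large (an 11-fold higher number from compound 1 to compound 2 (1.04 log units; beyond the scatter)). Compound 3 shares oxygen and fluorine on that ring with compound 1, so a moderate move to a lower number is expected (a 2.8-fold lower number from compound 2 to compound 3 (0.44 log units; beyond the scatter)). In this assay compound 3 is estimated at 550 nM (expected range 150 nM to 1800 nM).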

Compound 3, half-maximal inhibitory concentration: 220 nM
Beside the measured number, compound 3's estimate is 2.5-fold (0.40 log units) above it; measured number inside the range.
By their numbers in this assay, from the lowest: compounds 1 and 3 (each within the scatter of the next); then compound 2.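

In this assay, the group at this place matters on a ring without fluorine too: trifluoromethoxy in place of methyl gives a 6.9-fold lower number from compound 2 to compound 3 (0.84 log units; beyond the scatter). Changing 3-fluoro-4-methoxyphenyl to 4-(trifluoromethoxy)phenyl gives a 1.6-fold higher number from compound 1 to compound 3 (0.20 log units; within the scatter), so the ring of compound 1 is not the only one that reaches this level. Nothing measured here gives a reason for either step. Still open, on these data alone, is how an amine or a carboxylic acid at this place would read, and whether a plain phenyl ring would stand nearer compound 2 or compound 3.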